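The compounds below may be only part of what the source reports. "The series", "measured", "known", "first", "only" and "open" are said of these compounds alone.

Two compounds of one shared core carry the same amide-linked chain ending in a phenyl ring, and both have been tested in a functional assay on U2OS cells (Homo sapiens) for inhibition, read by CCK-8 assay, with a stated time of 72 h, tested at 1 uM; a higher number here means more inhibition at the concentration tested (going by the name of the read-out), a lower number less inhibition. Compound 1 `O=C(NCCCCc1ccccc1)c1cccc(C2SCC(=O)N2c2cccc(F)c2)c1` gives 39% in this assay. Compound 2 `CCOc1ccccc1N1C(=O)C(C)SC1c1cccc(C(=O)NCCCCc2ccccc2)c1` gives 37% in this assay. Of these two numbers, compound 1 holds the higher one, but compound 2 lies within the scatter of it, so the two read as the same level of inhibition.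

Compound 3 `CC(F)(F)c1cccc(N2C(=O)CSC2c2cccc(C(=O)NCCCCc3ccccc3)c2)c1` has not yet been measured in this assay. Next to compound 1 its change is 1,1-difluoroethyl in place of fluoro on an aromatic carbon. Within the data shown here, no measured pair shows what this kind of change does here, so there is no basis for expecting a shift beyond the scatter in either direction. The step from compound 1 to compound 3 is therefore expected to be close to none, a number 1 percentage points lower from compound 1 to compound 3 (within the scatter). Compound 3 is estimated to give 38% in this assay, in the range from 20% to 56%.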

Compound 3, a percentage reported as inhibition, at one concentration (the size of the read-out at that concentration, not a potency): 24%
Estimate against measurement, compound 3: 14 percentage points above, and the stated range covers the measured number.
By their numbers in this assay, from the lowest: compound 3; then compounds 2 and 1 (each within the scatter of the next).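

Among these compounds, this position on the aromatic ring is not indifferent to what sits on it: in this assay, putting 1,1-difluoroethyl in place of fluoro gives a number 15 percentage points lower from compound 1 to compound 3 (beyond the scatter) and is the first single-place change measured here. The entering group has 4 heavy atoms against 1 heavy atom for fluoro, but one pair cannot separate the effect of that difference from any other difference between the two groups. No measurement shown accounts for the step.

Going by these compounds, it remains open whether inhibition falls with this particular group or with other replacements for fluoro, such as a methyl, a trifluoromethyl or an amine at the same place. On these data alone, with only one tested concentration, these numbers give the size of the read-out there and not a potency, so the step at other concentrations also remains open.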